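This account rests on a few compounds, and the source may have more. Where it says the series, first, only, none or still open, it means among the compounds named here.

Measured so far in a functional assay on A549 cells (Homo sapiens) for cytotoxicity, read by sulforhodamine B assay, with a stated time of 72 h; on this read-out lower numbers stand for stronger inhibition and higher numbers for weaker inhibition:
- compound 1 `Cc1cc(C)nc(NS(=O)(=O)c2ccc(N3C(=O)/C(=C/c4coc5ccccc5c4=O)N=C3c3ccc(Cl)cc3)cc2)n1`: in this assay compound 1 gives 52600 nM
- compound 2 `Cc1cc(NS(=O)(=O)c2ccc(N3C(=O)/C(=C/c4coc5ccccc5c4=O)N=C3c3ccc(Cl)cc3)cc2)no1`: in this assay compound 2 gives only a limit of the assay, > 100000 nM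
- compound 3 `Cc1cc(C)nc(NS(=O)(=O)c2ccc(NC3=NC(=O)/C(=C\c4coc5ccccc5c4=O)S3)cc2)n1`: in this assay compound 3 gives only a limit of the assay, > 100000 nM

The cores of compound 1 and compound 3 differ in a way that is not broken down here. Between compound 1 and compound 2 the change is 5-methyl-1,2-oxazol-3-yl in place of 4,6-dimethylpyrimidin-2-yl on a sulfonamide nitrogen, and the step is an at least 1.9-fold higher number from compound 1 to compound 2 (0.27 log units; that floor lies within the scatter); its floor stays within the scatter, so the direction is only weakly indicated.

Compound 4 `Cc1cc(NS(=O)(=O)c2ccc(NC3=NC(=O)/C(=C\c4coc5ccccc5c4=O)S3)cc2)no1` carries the same change on the core of compound 3: 5-methyl-1,2-oxazol-3-yl in place of 4,6-dimethylpyrimidin-2-yl on a sulfonamide nitrogen. The place lines of the two changes match word for word, so this is the same change, now set against a starting compound that already sits at the limit. Of the values shown, two already rest at the limit of > 100000 nM in this assay, at which 2 of the 3 values shown sit. For compound 4 the step is expected to be about a step that the limit leaves unreadable from compound 3 to compound 4, a value that is estimated to lie at the limit as well, at around 150000 nM with an expected span from 70000 nM to 400000 nM.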

Compound 4, half-maximal inhibitory concentration: > 100000 nM
Compound 4: no number, only a limit; the forecaster's own chance of this, stated with the estimate: 90%; the middle value is on the limit's open side.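

The step between compound 3 and compound 4 cannot be read, since both values are limits in this assay, so neither size nor direction follows for this sulfonamide change: the limit of > 100000 nM in this assay, at which 3 of the 4 values shown sit.

The compounds shown leave open whether 5-methyl-1,2-oxazol-3-yl in place of 4,6-dimethylpyrimidin-2-yl has any readable effect on the core of compound 3.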